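Fluorinated benzyl in place of isopropylbenzyl on a coumarin amine

The source may report more compounds than this note shows. Statements on the series, on what has been measured and on what is new or still open speak of the compounds shown alone.

Measured compounds:
compound 1, `C#CCN(CCCCOc1ccc2ccc(=O)oc2c1)Cc1cccc(F)c1`: 1550 nM
compound 2, `C#CCN(CCCCOc1ccc2ccc(=O)oc2c1)Cc1ccc(C(C)C)cc1`: 3500 nM
compound 3, `C#CCN(CCCOc1ccc2ccc(=O)oc2c1)Cc1ccc(F)c(F)c1`: 4860 nM

In an assay on isolated protein for inhibition of Amine oxidase [flavin-containing] B (Homo sapiens), read by fluorescence and Amplex Red, with stated times of 15 min and 20 min (on this read-out lower numbers stand for stronger inhibition and higher numbers for weaker inhibition), compound 2 gives 3500 nM, the second highest number among the measured compounds. Compound 3 lies nearest to it, within the scatter of repeated measurements, while compound 1 gives a number lower by a 2.3-fold higher number from compound 1 to compound 2 (0.35 log units; beyond the scatter) reversed, a gap beyond the scatter. Compound 4, `C#CCN(CCCCOc1ccc2ccc(=O)oc2c1)Cc1ccc(F)c(F)c1`, is not yet measured. It differs from compound 2 in one place: 3,4-difluorophenyl in place of 4-isopropylphenyl on a saturated chain carbon bound to an amine nitrogen. Going by the values given here, the only measured step that bears on this change is the one from a fluorine-bearing phenyl to the isopropylphenyl, a 2.3-fold higher number from compound 1 to compound 2 (0.35 log units; beyond the scatter), which raised the number modestly. Running that change backwards, with a difluorophenyl entering instead, a modest drop in the number is expected for compound 4, a 1.8-fold lower number from compound 2 to compound 4 (0.24 log units; within the scatter). Compound 3 carries the same difluorophenyl on a shorter chain, and its value tempers the expectation. Compound 4 is therefore estimated at 2000 nM, with a range from 700 nM to 5500 nM.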

Compound 4, half-maximal inhibitory concentration: 2370 nM
Beside the measured number, compound 4's estimate is 1.2-fold (0.07 log units) below it, and the stated range covers the measured number.
By their numbers in this assay, from the lowest: compounds 1, 4, 2 and 3 (each within the scatter of the next, the first and the last beyond it).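

In this assay the exchange of 4-isopropylphenyl for 3,4-difluorophenyl on a saturated chain carbon bound to an amine nitrogen gives a 1.5-fold lower number from compound 2 to compound 4 (0.17 log units; within the scatter) and the added fluoro in place of hydrogen on an aromatic carbon gives a 1.5-fold higher number from compound 1 to compound 4 (0.18 log units; within the scatter) and so neither change separates compound 4 from the compound it is compared with. The earlier step of a 2.3-fold higher number from compound 1 to compound 2 (0.35 log units; beyond the scatter) remains the only one of the three at this position that lies beyond the scatter, and compound 4 falls within the scatter of both its ends. No measurement here explains how these groups compare. Going by these compounds, whether a pyridine ring, or a methoxy or trifluoromethyl group in place of the fluoro, would give a step beyond the scatter stays open. Also open, on these data alone, is how these benzyl groups behave with a longer chain.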